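The compounds below may be only part of what the source reports. "The series", "measured", "known", "first", "only" and "open" are said of these compounds alone.

Compound 1 `COc1ccc(/C=C/c2cc(OC)cc(OC)c2/C=C/C(=O)c2ccccc2)cc1`: 6.8 ug/mL
Compound 2 `COc1ccc(/C=C/c2cc(OC)cc(OC)c2/C=C/C(=O)c2cccc(Br)c2)cc1`: 13 ug/mL
Compound 3 `COc1ccc(/C=C/c2cc(OC)cc(OC)c2/C=C/C(=O)c2cccc(Cl)c2)cc1`: 9.5 ug/mL

All three were read in a functional assay on HepG2 cells (Homo sapiens) for antiproliferative activity, read by MTT assay, with a stated time of 48 h; on this read-out lower numbers stand for stronger inhibition and higher numbers for weaker inhibition. Compound 3 stands second highest of the three numbers; its nearest neighbour is compound 2 (a 1.4-fold lower number from compound 2 to compound 3 (0.14 log units; within the scatter)) and the furthest compound 1 (a 1.4-fold higher number from compound 1 to compound 3 (0.15 log units; within the scatter)). The three differ only in the group on the carbonyl carbon, and every step among them, also a 1.9-fold higher number from compound 1 to compound 2 (0.28 log units; within the scatter), stays within the scatter.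

Compound 4 `COc1ccc(/C=C/c2cc(OC)cc(OC)c2/C=C/C(=O)c2ccc(C)cc2C)cc1` is not yet measured. Its change from compound 3: 2,4-dimethylphenyl in place of 3-chlorophenyl on a carbonyl carbon. For the measured compounds named here, no measured step makes this change; the steps with bromo or chloro in place of hydrogen and chloro in place of bromo are the only guide, and all were within the scatter. No step beyond the scatter is therefore expected in this assay; the expected step is a 1.1-fold lower number from compound 3 to compound 4 (0.02 log units; within the scatter). Compound 4 is estimated at 9 ug/mL, range 4 ug/mL to 20 ug/mL.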

Compound 4, half-maximal inhibitory concentration: 0.9 ug/mL
Estimate against measurement, compound 4: 10-fold (1.00 log units) above; the whole stated range lies above it.
By their numbers in this assay, from the lowest: compound 4; then compounds 1, 3 and 2 (each within the scatter of the next).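

The group on the carbonyl carbon does move the number in this assay: 2,4-dimethylphenyl gives steps beyond the scatter against all three earlier groups (an 11-fold lower number from compound 3 to compound 4 (1.02 log units; beyond the scatter)) and (a 14-fold lower number from compound 2 to compound 4 (1.16 log units; beyond the scatter)) and (a 7.6-fold lower number from compound 1 to compound 4 (0.88 log units; beyond the scatter)), whereas phenyl, 3-chlorophenyl and 3-bromophenyl stayed within the scatter of each other. Nothing measured here explains this step.

From the compounds shown here alone, with both methyl groups entering together, the share of each stays open. Going by these compounds, how a single methyl, a methoxy group or an amine on that phenyl ring would read also stays open.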